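Series notes: phenyl to pyridin-2-yl on the amine

A few compounds are considered here, and "the series" means these few. Any claim that something is new, unique, unknown or untested is made for them only; others in the source may bear on it.

Of the compounds shown here, three of the shared core have been measured in a physicochemical assay for lipophilicity, read by HPLC; on this read-out higher numbers stand for higher lipophilicity and lower numbers for lower lipophilicity. Compound 1 `CC(=O)NC[C@H]1CN(c2ccc(OC[C@@H](O)CNc3ccccc3)c(F)c2)C(=O)O1` gives 1.42, the lowest of the three numbers. Compound 2 `CC(=O)NC[C@H]1CN(c2ccc(OC[C@@H](O)CNc3cc(C(F)(F)F)cc(C(F)(F)F)c3)c(F)c2)C(=O)O1` gives 3.1 and compound 3 `CC(=O)NC[C@H]1CN(c2ccc(OC[C@H](O)CNc3cc(C(F)(F)F)cc(C(F)(F)F)c3)c(F)c2)C(=O)O1` gives 3.01, both well above compound 1 and beyond the scatter. For the measured compounds named here, the only single-point step among the measured compounds is a number 0.09 log units lower from compound 2 to compound 3 (within the scatter); it rests on the fact that compounds 2 and 3 differ only in the configuration as drawn and does not touch the ring on the amine nitrogen, so it carries no information on the change considered here.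

Compound 4 `CC(=O)NC[C@H]1CN(c2ccc(OC[C@@H](O)CNc3ccccn3)c(F)c2)C(=O)O1` differs from compound 1 in one place: pyridin-2-yl in place of phenyl on an amine nitrogen. Going by the values given here, no measured step covers this exchange, so the expectation rests on compound 1 alone in this assay, with no evidence for the size of the step. A moderate move to lower lipophilicity is expected, a number 0.72 log units lower from compound 1 to compound 4 (beyond the scatter), with wide uncertainty. Compound 4 is therefore estimated at 0.7, in the range 0.1 to 1.3.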

Compound 4, partition coefficient: 1.37
The estimate for compound 4 lay 0.67 log units below the measured number; the whole stated range lies below it.
By their numbers in this assay, from the lowest: compounds 4 and 1 (each within the scatter of the next); then compounds 3 and 2 (each within the scatter of the next).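

In this assay, for the compounds shown here, pyridin-2-yl in place of phenyl on an amine nitrogen gives a number 0.05 log units lower from compound 1 to compound 4 (within the scatter) and is the first reading of any exchange at this position. In this one pair, a ring nitrogen and one added hydrogen-bond acceptor leave the number within the scatter of the phenyl compound, on an amine nitrogen whose other neighbour is a saturated chain carbon. Nothing in hand bears on why the two numbers stay together.

Open, on these data alone, is whether pyridin-3-yl or pyrimidin-2-yl on the same amine nitrogen would also stay this close to compound 1. Also open, as far as these compounds go, is whether the exchange reads the same when the ring carries two trifluoromethyl groups, as in compound 2, since a single pair sets no pattern for the series.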